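This account rests on a few compounds, and the source may have more. Where it says the series, first, only, none or still open, it means among the compounds named here.

In an ADME assay on Huh-7 cells (Homo sapiens) for cytotoxicity, read by MTT assay, with a stated time of 72 h (a higher number here means that more compound is tolerated, a lower number that less compound is tolerated), compound 3 `Cc1cc(=O)oc2cc(OCc3cn(-c4cccc(F)c4)nn3)ccc12` gives > 100 ug/mL, which is a limit of the assay and not a number. Compound 1 `Cc1cc(=O)oc2cc(OCc3cn(-c4ccccc4F)nn3)ccc12` gives > 100 ug/mL, likewise a limit. Compound 2 `Cc1cc(=O)oc2cc(OCc3cn(-c4ccccc4[N+](=O)[O-])nn3)ccc12` gives > 100 ug/mL, again a limit. All three values sit at the limit of > 100 ug/mL in this assay, at which 3 of the 3 values shown sit, so the steps a step that the two limits leave unreadable from compound 1 to compound 2, a step that the two limits leave unreadable from compound 1 to compound 3 and a step that the two limits leave unreadable from compound 2 to compound 3 cannot be read for size or direction. Compound 4 `Cc1cc(=O)oc2cc(OCc3cn(CCO)nn3)ccc12` differs from compound 3 by 2-hydroxyethyl in place of 3-fluorophenyl on an aromatic nitrogen. Going by the values given here, none of the measured steps replaces the group on the aromatic nitrogen with a chain, so none bears directly on this change, and the three measured steps offer no readable size. For compound 4 the expectation is that the read-out again reaches the limit, estimated at 100 ug/mL with a range of 60 ug/mL to 200 ug/mL. The step from compound 3 to compound 4 is thus expected to be a number no higher from compound 3 to compound 4 (the limit leaves the size open), none beyond the scatter.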

Compound 4, half-maximal cytotoxic concentration: > 100 ug/mL
Compound 4: no number, only a limit (the forecaster's own chance of this, stated with the estimate: 85%); the middle value sits exactly at the limit.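

Compound 4 gives > 100 ug/mL, a limit and not a number, so its steps from compound 1, compound 2 and compound 3 cannot be read: the limit of > 100 ug/mL in this assay, at which 4 of the 4 values shown sit.

The compounds shown leave open where any half-maximal cytotoxic concentration actually lies, and whether the group on the aromatic nitrogen changes it.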